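The source may report more compounds than this note shows. Statements on the series, on what has been measured and on what is new or still open speak of the compounds shown alone.

Measured so far in a physicochemical assay for solubility, in phosphate buffer, at pH 7.4; on this read-out lower numbers stand for lower solubility and higher numbers for higher solubility:
- compound 1 `COc1cc(F)ccc1-c1ccnc2[nH]c(C3CCN(CC(=O)N(C)C)CC3)cc12` gives 38000 nM
- compound 2 `CC(C)n1cc(-c2ccnc3[nH]c(C4CCN(CC(=O)N(C)C)CC4)cc23)cnc1=O` gives 910000 nM
- compound 3 `CC(C)n1cc(-c2ccnc3[nH]c(C4CCN(CC(=O)N(C)C)CC4)cc23)ccc1=O` gives 110000 nM

Compound 3 stands second highest of these three, and its nearest neighbour on the numbers is compound 1. Compound 4 `COc1cc(=O)n(C)cc1-c1ccnc2[nH]c(C3CCN(CC(=O)N(C)C)CC3)cc12` has not yet been measured. It differs from compound 3 by one exchange (a group of 10 heavy atoms (7 carbon, 1 nitrogen, 2 oxygen; one six-membered aromatic ring with 1 hetero atom) in place of a group of 10 heavy atoms (8 carbon, 1 nitrogen, 1 oxygen; one six-membered aromatic ring with 1 hetero atom), on an aromatic carbon). The exchange sits on an aromatic carbon of a six-membered aromatic ring with 1 nitrogen, part of a fused or bridged system of two rings. The three measured compounds differ from one another at that same place, so all three measured steps bear on it. The step that avoids the group with 2 hetero atoms in its ring is modest (a 2.9-fold higher number from compound 1 to compound 3 (0.46 log units; beyond the scatter)). The two steps involving that group are wider (a 24-fold higher number from compound 1 to compound 2 (1.38 log units; beyond the scatter)) and (an 8.3-fold lower number from compound 2 to compound 3 (0.92 log units; beyond the scatter)). Both groups in the present exchange hold 1 hetero atom in the ring, so a shift smaller than any of these is expected, leaning slightly upward from compound 3 (110000 nM). The expected step is small (a 1.8-fold higher number from compound 3 to compound 4 (0.26 log units; within the scatter)). For compound 4 the estimated value is 200000 nM in this assay, with an expected range from 70000 nM to 600000 nM.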

Compound 4, solubility: 670000 nM
Beside the measured number, compound 4's estimate is 3.4-fold (0.53 log units) below it, and the stated range ends below it.
By their numbers in this assay, from the lowest: compound 1; then compound 3; then compounds 4 and 2 (each within the scatter of the next).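

In this assay, the groups in this exchange, on an aromatic carbon opposite the ring nitrogen, both hold 1 hetero atom in the ring, yet the reading is a 6.1-fold higher number from compound 3 to compound 4 (0.78 log units; beyond the scatter), so among these compounds the count of ring hetero atoms alone does not set the number at this place. Compound 2 goes against any reading by that count, since its group holds 2 hetero atoms in the ring and the comparison still gives a 1.4-fold lower number from compound 2 to compound 4 (0.13 log units; within the scatter), while the carbon-only ring of compound 1 remains apart at an 18-fold higher number from compound 1 to compound 4 (1.25 log units; beyond the scatter). No measurement offered here explains why these groups differ.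

The entering group holds one carbon fewer and one oxygen more than the leaving group and counts 3 hydrogen-bond acceptors against 2, and the compounds shown cannot say which part of that exchange carries the step. On these data alone, how a group such as an amine or a carboxylic acid at this place would read in this assay, and whether these steps would hold on another core, also remains open.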